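Cyanosulfanyl in Place of Hydrogen: Expected Effect on Cytotoxicity

The source may hold more compounds than are shown below. What is called first, only, known or untested is meant among the compounds shown, and "the series" means these compounds.

Two compounds of this series have readings in a functional assay on HeLa cells (Homo sapiens) for cytotoxicity, with a stated time of 72 h; a lower number here means a stronger inhibitor, a higher number a weaker inhibitor. Compound 1 `O=c1oc2ccccc2cc1-c1cn2nc(Cc3ccc(Cl)cc3)sc2n1` reaches only the assay's limit, giving > 10000 nM in this assay. Compound 2 `Clc1ccc(Cc2nn3c(Br)c(-c4ccccc4)nc3s2)cc1` also sits at a limit, with > 250000 nM in this assay. Among the compounds with values here, compound 1 thus stands at a limit rather than at a measured number, the position marked by the limit of > 10000 nM in this assay, at which 1 of the 2 values shown sits, and no step between measured compounds can be sized from these two readings. Compound 3 `N#CSc1c(-c2cc3ccccc3oc2=O)nc2sc(Cc3ccc(Cl)cc3)nn12` differs from compound 1 by a single change: cyanosulfanyl in place of hydrogen on an aromatic carbon. Within the data shown here, with compound 1 at a limit, no measured step guides the outlook, and this change is not expected to shift the reading in a clear direction beyond the scatter. Compound 3 is expected to give 20000 nM, with a range from 4000 nM to 100000 nM. The expected step is a step that the limit leaves unreadable from compound 1 to compound 3, and a reading reported only as a limit is again considered the most likely result.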

Compound 3, half-maximal inhibitory concentration: 1000 nM
For compound 3 the middle estimate is 20-fold (1.30 log units) above the measured one, outside the stated range (below it).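

The change from hydrogen to cyanosulfanyl gives the series its first readable step: in this assay it produces an at least 10-fold lower number from compound 1 to compound 3 (1.00 log units; beyond the scatter). This shows that the aromatic carbon next to the ring nitrogen is a position where a single substitution on the core of compound 1 can move the reading beyond the scatter, which neither earlier reading could show. The step can be given only as a lower bound, because compound 1 stands at a limit and not at a measured number: the limit of > 10000 nM in this assay, at which 1 of the 3 values shown sits.

On these data alone, how large the step really is therefore stays open. Also open, as far as these compounds go, is whether the effect needs the whole cyanosulfanyl group or would also appear with a smaller group at this carbon, such as an amine or methylsulfanyl.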